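The source may report more compounds than this note shows. Statements on the series, on what has been measured and on what is new or still open speak of the compounds shown alone.

Measured so far:
compound 1 `COc1ccc(C(=O)/C=C/c2ccc(N(C)C)cc2)c2c1C=CC(C)(C)O2` — 3500 nM
compound 2 `COc1ccc(C(=O)/C=C/c2ccccc2)c2c1C=CC(C)(C)O2` — > 10000 nM

Within the data shown here, in a functional assay on K562 cells (Homo sapiens) for antiproliferative activity, read by MTT assay, with a stated time of 24 h (on this read-out lower numbers stand for stronger inhibition and higher numbers for weaker inhibition), compound 1 gives 3500 nM, the only numerical value among the two measured compounds. For compound 2 the result is a limit of the assay, > 10000 nM. Among the measured compounds shown here, the single measured step, an at least 2.8-fold higher number from compound 1 to compound 2 (0.45 log units; beyond the scatter), shows that removing the dimethylamino group costs activity; how far the loss goes is open, since the weaker compound sits at the limit of > 10000 nM in this assay, at which 1 of the 2 values shown sits.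

Compound 3 `COc1ccc(C(=O)/C=C/c2ccc(O)cc2)c2c1C=CC(C)(C)O2` carries the change (hydroxy in place of dimethylamino on an aromatic carbon). This step overlaps with the measured one: the dimethylamino group leaves in both cases, but here a hydroxy group enters instead of hydrogen. The measured step sets the scale for losing dimethylamino; whether a hydroxy group recovers any part of that loss cannot be read from the two measured compounds. The expected step in this assay is a 2.0-fold higher number from compound 1 to compound 3 (0.30 log units; within the scatter), a loss beyond the scatter, judged likely to fall short of the measured step. For compound 3 the estimate is 7000 nM, with a range from 3000 nM to 20000 nM, and a fair chance that only a limit is returned.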

Compound 3, half-maximal inhibitory concentration: > 10000 nM
Compound 3: no number, only a limit; the forecaster's own chance of this, stated with the estimate: 35%; middle value at least 1.4-fold (0.15 log units) away from the limit.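

Hydroxy on this aromatic carbon does not preserve the activity seen with dimethylamino: in this assay, the change gives an at least 2.8-fold higher number from compound 1 to compound 3 (0.45 log units; beyond the scatter). The earlier step showed only that activity falls when dimethylamino gives way to hydrogen; this result shows the same direction with a replacement that has a hydrogen-bond donor, so the presence of a substituent alone does not keep a measurable value. Among the three compounds, only the 4-(dimethylamino)phenyl compound, compound 1, gives a number, while the other two reach the same assay limit: the limit of > 10000 nM in this assay, at which 2 of the 3 values shown sit.

The step between compound 2 and compound 3 cannot be read, and neither can any ranking of hydrogen against hydroxy, nor whether one of these losses exceeds the other. From the compounds shown here alone, whether activity depends on the amine nitrogen or on its two carbons also remains open, and a primary amine or a diethylamino group on the same aromatic carbon would address that question directly.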